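A few compounds are considered here, and "the series" means these few. Any claim that something is new, unique, unknown or untested is made for them only; others in the source may bear on it.

Compound 1 `CCOC(=O)[C@@H]1/C(=C/C(=O)c2ccc(F)cc2)N=C(C)/C(=C(/O)OCC)[C@H]1c1ccccc1C(F)(F)F` gives 117 nM in an assay on brain for binding affinity to Voltage-gated L-type calcium channel (Rattus norvegicus); on this read-out lower numbers stand for stronger inhibition and higher numbers for weaker inhibition; compound 2 `CCOC(=O)[C@@H]1/C(=C/C(=O)c2ccc(N(C)C)cc2)N=C(C)/C(=C(/O)OCC)[C@H]1c1ccccc1C(F)(F)F` gives 31.7 nM in this assay; compound 3 `CCOC(=O)[C@@H]1C(/C=C(\O)c2ccccc2)=NC(C)=C([N+](=O)[O-])[C@H]1c1ccccc1C(F)(F)F` gives 336 nM in this assay.

Compound 3 stands at the highest number of the three in this assay: next to it is compound 1, and furthest from it is compound 2, both with steps beyond the scatter. Compound 4 `CC1=C([N+](=O)[O-])[C@@H](c2ccccc2C(F)(F)F)[C@H](C(=O)c2ccccc2)C(/C=C(\O)c2ccccc2)=N1` differs from compound 3 in one place: phenyl in place of ethoxy on a carbonyl carbon, so that ethoxycarbonyl becomes benzoyl. Within the data shown here, the only single-point step among the measured compounds, a 3.7-fold lower number from compound 1 to compound 2 (0.57 log units; beyond the scatter), concerns a substituent on the aromatic ring of the side chain and does not touch the carbonyl carbon changed here, so it gives no guide to this exchange. Among the measured compounds shown here, no measured pair shows what replacing ethoxy by phenyl at this position does in this assay. The expectation for compound 4 therefore rests on compound 3 alone, with a wide range: the estimated step is a 1.1-fold lower number from compound 3 to compound 4 (0.05 log units; within the scatter), which is expected not to lie beyond the scatter in either direction. Compound 4 is estimated at 300 nM, between 80 nM and 1200 nM.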

Compound 4, half-maximal inhibitory concentration: > 1000 nM
Compound 4: a limit, no number (the forecaster's own chance of this, stated with the estimate: 5%); middle value at least 3.3-fold (0.52 log units) from the limit.
By their numbers in this assay, from the lowest: compound 2; then compound 1; then compound 3. At a limit, above all of these: compound 4.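

Compound 4 gives a limit of the assay and not a number: the limit of > 1000 nM in this assay, at which 1 of the 4 values shown sits. The substituent on this carbonyl carbon therefore matters in this assay: phenyl in place of ethoxy, which turns ethoxycarbonyl into benzoyl, gives an at least 2.9-fold higher number from compound 3 to compound 4 (0.47 log units; beyond the scatter). This is the only step shown at this position, and the earlier step on the aromatic ring of the side chain could not show that this exchange moves the number upward.

On these data alone, how far the number rises past the limit stays open, so the full size of the step cannot be stated. Also open, as far as these compounds go, is whether a methoxy, a benzyloxy or an amine on this carbonyl carbon would stay close to compound 3 or move the same way as phenyl.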